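The source may report more compounds than this note shows. Statements on the series, on what has been measured and on what is new or still open speak of the compounds shown alone.

The measured compounds, as they stand:

Compound 1, `C=C1CC[C@H]2C(C)(C)CCC[C@]2(C)[C@H]1CCC(C)CC(=O)OC`, in a functional assay on K562 cells (Homo sapiens) for cytotoxicity, read by MTT assay, with a stated time of 24 h (a lower number here means a stronger inhibitor, a higher number a weaker inhibitor), gives > 200000 nM, which is a limit of the assay and not a number.
Compound 2, `COc1ccc(/C=C2\CC[C@H]3C(C)(C)CCC[C@]3(C)[C@H]2CCC(C)CC(=O)O)cc1`, in this assay gives > 200000 nM, again a limit rather than a number.
Compound 3, `CC(CC[C@H]1/C(=C/c2ccc([N+](=O)[O-])cc2)CC[C@H]2C(C)(C)CCC[C@]12C)CC(=O)O`, in this assay gives > 200000 nM, also a limit and not a number.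

Compound 3 thus stands at the edge of what this assay can report, and nothing separates it from compound 1 or compound 2, since all three values rest at the limit of > 200000 nM in this assay, at which 3 of the 3 values shown sit. Going by the values given here, the single one-point step that is available, a step that the two limits leave unreadable from compound 2 to compound 3, has no readable size; both of its ends are limits.

Compound 4, `CC(CC[C@H]1/C(=C/c2ccc(Cl)cc2)CC[C@H]2C(C)(C)CCC[C@]12C)CC(=O)O`, is compound 3 with one change: chloro in place of nitro on an aromatic carbon. Among the compounds with values here, the only measured step that bears on this change is the one from compound 2 to compound 3, and it gives no size at all. With every value shown sitting at the limit of > 200000 nM in this assay, at which 3 of the 3 values shown sit, the expectation for compound 4 is that it also stays at that limit, so the expected step is a step that the limit leaves unreadable from compound 3 to compound 4. Compound 4 is therefore estimated at 300000 nM, with a range from 120000 nM to 1000000 nM, and most likely the assay again reports only a limit.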

Compound 4, half-maximal inhibitory concentration: > 200000 nM
Compound 4 gave a limit, no number; the forecaster's own chance of this, stated with the estimate: 80%; the middle value is on the limit's open side.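

In this assay compound 4 gives > 200000 nM, again a limit and not a number. Its steps from compound 2 and from compound 3 therefore cannot be read, and neither has a size: the limit of > 200000 nM in this assay, at which 4 of the 4 values shown sit.

The compounds shown leave open whether any group on the aromatic ring, or any change to the shared core, would give a measurable value in this assay.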